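Ethyl to hydrogen on the ring amine nitrogen

The source may report more compounds than this note shows. Statements on the series, on what has been measured and on what is new or still open speak of the compounds shown alone.

Compound 1 `Cc1ccccc1Nc1nc(Nc2ccccn2)ncc1Cl`, compound 2 `Cc1ccccc1Nc1nc(Nc2ccc(N3CCN(C)CC3)cn2)ncc1Cl` and compound 3 `CCN1CCN(c2ccc(Nc3ncc(Cl)c(Nc4ccccc4C)n3)nc2)CC1` share one core and differ only in the group on the aromatic carbon. In a functional assay on MDA-MB-231 cells (Homo sapiens) for inhibition, read by CCK-8 assay, with a stated time of 48 h (on this read-out higher numbers stand for weaker inhibition of growth and lower numbers for stronger inhibition of growth), compound 1 gives 11200 nM and compound 2 gives 7470 nM; the step of a 1.5-fold lower number from compound 1 to compound 2 (0.18 log units; within the scatter) stays within the scatter. For compound 3 the value > 100000 nM is a limit of the assay and not a number (the limit of > 100000 nM in this assay, at which 1 of the 3 values shown sits). Compound 3 thus stands at the weak end of the three, since an at least 8.9-fold higher number from compound 1 to compound 3 (0.95 log units; beyond the scatter) and an at least 13-fold higher number from compound 2 to compound 3 (1.12 log units; beyond the scatter) both lie beyond the scatter.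

Compound 4 `Cc1ccccc1Nc1nc(Nc2ccc(N3CCNCC3)cn2)ncc1Cl` differs from compound 3 by hydrogen in place of ethyl on an amine nitrogen in a ring. The measured step that bears on this is an at least 13-fold higher number from compound 2 to compound 3 (1.12 log units; beyond the scatter), where methyl in place of hydrogen on that ring nitrogen cost much; returning to hydrogen is expected to undo that cost. For the measured compounds named here, no measured compound carries the unsubstituted group, so the estimate leans on compound 2 at 7470 nM and compound 1 at 11200 nM. Compound 4 is expected to fall near those two, giving an at least 10-fold lower number from compound 3 to compound 4 (1.00 log units; beyond the scatter), with an estimate of 10000 nM and a range from 3000 nM to 40000 nM.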

Compound 4, concentration for 50% growth inhibition: 5060 nM
The estimate for compound 4 lay 2.0-fold (0.30 log units) above the measured number; low and high end bracket the measured number.
By their numbers in this assay, from the lowest: compounds 4, 2 and 1 (each within the scatter of the next, the first and the last beyond it). At a limit, above all of these: compound 3.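

Compound 3 still sits at a limit of the assay and not at a number: the limit of > 100000 nM in this assay, at which 1 of the 4 values shown sits.

In this assay hydrogen on the ring amine nitrogen gives an at least 19-fold lower number from compound 3 to compound 4 (1.29 log units; beyond the scatter) and so places the sharp loss with ethyl, while hydrogen in place of methyl gives a 1.5-fold lower number from compound 2 to compound 4 (0.17 log units; within the scatter) and leaves those two substituents unseparated. Piperazin-1-yl in place of hydrogen on the aromatic carbon gives a 2.2-fold lower number from compound 1 to compound 4 (0.35 log units; beyond the scatter) and is thus a modest gain over the unsubstituted parent, whereas 4-methylpiperazin-1-yl stayed within the scatter of that parent.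

For the compounds shown here, with ethyl as the only group larger than methyl on this nitrogen, it remains open whether the loss follows chain length or is peculiar to ethyl. A propyl chain, a 2-hydroxyethyl chain or an acetyl group on the same nitrogen would address this, and the compounds shown offer no cause for the loss.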